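The source may report more compounds than this note shows. Statements on the series, on what has been measured and on what is new or still open speak of the compounds shown alone.

Compound 2 `NS(=O)(=O)c1ccc2nc(N3N=C(c4ccc(Cl)cc4)CC3c3ccc(Cl)cc3)sc2c1` is the lower of the two compounds measured in a functional assay on the whole organism (strain Wistar) for inhibition, with Rattus norvegicus as the target, read by paw edema, with stated times of 1 h and 5 h, at a dose of 20 mg/kg by the oral route; a lower number here means less inhibition, a higher number more inhibition at the dose given (going by the name of the read-out). Compound 2 gives 14%, while compound 1 `NS(=O)(=O)c1ccc2nc(N3N=C(c4ccc(Cl)cc4)CC3c3ccccc3)sc2c1` gives 68.3%. Among the compounds with values here, the one step measured so far, a number 54.3 percentage points lower from compound 1 to compound 2 (beyond the scatter), came with the change from compound 1 to compound 2.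

Compound 3 `NS(=O)(=O)c1ccc2nc(N3N=C(c4ccc(Cl)cc4)CC3c3ccccc3Cl)sc2c1` has not yet been measured in this assay. The change from compound 2 to compound 3 is 2-chlorophenyl in place of 4-chlorophenyl on a saturated ring carbon. Within the data shown here, no measured pair shows what moving the chlorine on that ring does, so the only step that bears on it is the one from compound 1 to compound 2, where adding a chlorine at that ring cost a large amount. Since that chlorine stays but sits elsewhere, part of that loss is expected to be recovered, so the estimate for compound 3 is 35% with a range of 10% to 65%, meaning an expected step of a number 21 percentage points higher from compound 2 to compound 3 (beyond the scatter).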

Compound 3, a percentage reported as inhibition, in the whole organism at one dose (the size of the read-out at that dose, not a potency): 14%
For compound 3 the middle estimate is 21 percentage points above the measured one; measured number inside the range.
By their numbers in this assay, from the lowest: compounds 2 and 3 (each within the scatter of the next); then compound 1.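

In this assay the shift from 4-chlorophenyl to 2-chlorophenyl brings no change at the digits printed from compound 2 to compound 3 (within the scatter) while adding the chlorine at the new place, starting from the compound without it, brings a number 54.3 percentage points lower from compound 1 to compound 3 (beyond the scatter) as well. The large loss seen earlier was therefore not tied to one location: among these three compounds, the drop appears with the chlorine at either of the two places tested on this ring, and compound 2 and compound 3 stand level. No measurement shown here explains why the chlorine has this effect.

On these data alone, what stays open is whether the loss belongs to chlorine itself or would also come with another group on this ring, such as fluoro, methoxy or an amine. A group of that kind would show whether any substituent there can keep the inhibition of compound 1.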